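Acyl variation on the amine of the shared core

The compounds below may be only part of what the source reports. "The series", "measured", "known", "first", "only" and "open" are said of these compounds alone.

The shared core carries an amine that is varied in three ways. Compound 1 `N#CC1=C(N)N(c2ccc(S(N)(=O)=O)cc2)C2=C(C(=O)CCC2)C1c1ccc(Cl)cc1Cl` has the free amine; in a functional assay on Ehrlich cells (Mus musculus) for cytotoxicity, read by trypan blue exclusion, with a stated time of 2 h, tested at 10 ug/mL (a lower number here means a weaker effect, a higher number a stronger effect of the compound at the concentration tested), compound 1 gives 40%. Compound 2 `N#CC1=C(NC(=O)c2ccccc2)N(c2ccc(S(N)(=O)=O)cc2)C2=C(C(=O)CCC2)C1c1ccc(Cl)cc1Cl` bears a benzoyl group, and in this assay compound 2 gives 50%; the step of a number 10 percentage points higher from compound 1 to compound 2 (within the scatter) is small. Compound 3 `COc1cc(C(=O)NC2=C(C#N)C(c3ccc(Cl)cc3Cl)C3=C(CCCC3=O)N2c2ccc(S(N)(=O)=O)cc2)cc(OC)c1OC` carries a 3,4,5-trimethoxyphenyl on the carbonyl carbon, and in this assay compound 3 gives 0%, the lowest of the three numbers.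

Compound 4 `CC(=O)CC(=O)NC1=C(C#N)C(c2ccc(Cl)cc2Cl)C2=C(CCCC2=O)N1c1ccc(S(N)(=O)=O)cc1` differs from compound 3 by 2-oxopropyl in place of 3,4,5-trimethoxyphenyl on a carbonyl carbon. Among the measured compounds shown here, the only measured step that changes the group on this carbonyl carbon is a number 50 percentage points lower from compound 2 to compound 3 (beyond the scatter), which was large, so a step beyond the scatter, upward, is expected here. The estimate for compound 4 in this assay is 30% with range 5% to 60%, an expected step of a number 30 percentage points higher from compound 3 to compound 4 (beyond the scatter).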

Compound 4, a percentage reported as activity, at one concentration (the size of the read-out at that concentration, not a potency): 40%
Compound 4: middle estimate off by 10 percentage points, on the low side, and the stated range covers the measured number.
By their numbers in this assay, from the lowest: compound 3; then compounds 1, 4 and 2 (each within the scatter of the next).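

In this assay the low number of compound 3 does not carry over to 2-oxopropyl on this carbonyl carbon: the change gives a number 40 percentage points higher from compound 3 to compound 4 (beyond the scatter). With a number 10 percentage points lower from compound 2 to compound 4 (within the scatter) and no change at the digits printed from compound 1 to compound 4 (within the scatter), compounds 1, 2 and 4 stand together, and among the four compounds only the 3,4,5-trimethoxyphenyl group stands apart. Nothing available explains this separation.

Open, on these data alone, is whether the methoxy groups or the substituted ring as a whole accounts for the low number. A phenyl with a single methoxy group, or a longer chain ending in an amine or a carboxylic acid, would test this.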